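Replacing Neopentyl When Clearance Sits at a Limit

This account rests on a few compounds, and the source may have more. Where it says the series, first, only, none or still open, it means among the compounds named here.

In an in vivo ADME assay on the whole organism for pharmacokinetics, with Rattus norvegicus as the target, at a dose of 2 mg/kg by the intravenous route (on this read-out lower numbers stand for slow clearance and higher numbers for fast clearance), compound 1 (`CC(C)(C)CCN1C(=O)C(C2=CS(=O)(=O)c3cc(NS(C)(=O)=O)ccc3N2)=C(O)[C@@H]1C(C)(C)C`) gives > 100 mL/min/kg, which is a limit of the assay and not a number.

Compound 4 (`CC(C)(C)[C@H]1C(O)=C(C2=CS(=O)(=O)c3cc(NS(C)(=O)=O)ccc3N2)C(=O)N1Cc1ccc(F)c(Cl)c1`) keeps the core of compound 1 and differs in one place: 3-chloro-4-fluorophenyl in place of neopentyl on a saturated chain carbon bound to an amide-type nitrogen in a ring.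

Two measured compounds carry related aromatic groups in that place. Compound 2 (`CC(C)(C)[C@H]1C(O)=C(C2=CS(=O)(=O)c3cc(NS(C)(=O)=O)ccc3N2)C(=O)N1Cc1ccc(F)cc1`) gives 101 mL/min/kg, and compound 3 (`Cc1cc(CN2C(=O)C(C3=CS(=O)(=O)c4cc(NS(C)(=O)=O)ccc4N3)=C(O)[C@@H]2C(C)(C)C)ccc1F`) gives 101 mL/min/kg. Neither comparison with compound 1 has a measurable size: one is a step that the limit leaves unreadable from compound 1 to compound 2, and the other is a step that the limit leaves unreadable from compound 1 to compound 3. Within the data shown here, the only readable step, a methyl in place of hydrogen on an aromatic carbon, shows no change at the digits printed from compound 2 to compound 3 (within the scatter).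

On that evidence, compound 4 is expected to remain a fast-clearing compound, close to compound 3 at 101 mL/min/kg. The expected step is an at least 1.0-fold lower number from compound 1 to compound 4 (0.03 log units; that floor lies within the scatter), which cannot be firmly sized against a limit. For compound 4, the estimated clearance is 92 mL/min/kg, with an expected range of 58 mL/min/kg to 135 mL/min/kg.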

Compound 4, clearance: 86 mL/min/kg
Compound 4: the middle estimate sits 1.1-fold (0.03 log units) above what was measured; the range from low to high includes it.
By their numbers in this assay, from the lowest: compounds 4, 2 and 3 (each within the scatter of the next).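

The change from neopentyl to 3-chloro-4-fluorophenyl gives the first step away from compound 1 that can be sized, though only as a floor: the result is an at least 1.1-fold lower number from compound 1 to compound 4 (0.06 log units; that floor lies within the scatter), while the steps to compound 2 and compound 3 cannot be read. Compound 1 stands at a limit of this assay and not at a number: the limit of > 100 mL/min/kg in this assay, at which 1 of the 4 values shown sits.

Among the aromatic groups, chloro in place of hydrogen gives a 1.2-fold lower number from compound 2 to compound 4 (0.07 log units; within the scatter), and chloro in place of methyl gives a 1.2-fold lower number from compound 3 to compound 4 (0.07 log units; within the scatter), so compounds 2, 3 and 4 cannot be told apart on clearance.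

On these data alone, whether a different kind of group at this place, such as an amine or a carboxylic acid, would give slower clearance remains open. So does the effect of a pyridine ring in place of the halogenated phenyl ring.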